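Chloro on the pendant phenyl across two related cores

The source may hold more compounds than are shown below. What is called first, only, known or untested is meant among the compounds shown, and "the series" means these compounds.

Of the compounds shown here, three have been measured in a functional assay on the whole organism (strain albino) for inhibition, with Rattus norvegicus as the target, read by paw edema, with stated times of 1 h and 3 h, at a dose of 100 mg/kg by the oral route; on this read-out lower numbers stand for a weaker effect and higher numbers for a stronger effect at the one dose given. Compound 1, `N#Cc1c(-c2ccccc2)nc(SCC(=O)Nn2c(COc3ccc(Cl)cc3Cl)nc3ccccc3c2=O)n(Cc2ccccc2)c1=O`, gives 79%. Compound 2, `N#Cc1c(-c2ccc(Cl)cc2)nc(SCC(=O)Nn2c(COc3ccc(Cl)cc3Cl)nc3ccccc3c2=O)n(Cc2ccccc2)c1=O`, gives 77.2% in this assay. The two differ only by chloro in place of hydrogen on an aromatic carbon, and that change gave a step of a number 1.8 percentage points lower from compound 1 to compound 2 (within the scatter). Compound 3, `N#Cc1c(Nc2ccccc2)nc(SCC(=O)Nn2c(COc3ccc(Cl)cc3Cl)nc3ccccc3c2=O)nc1-c1ccccc1`, is built on a different core; the difference between the two cores is not broken down here. In this assay compound 3 gives 78.1%, and its values against compound 1 and compound 2 are within the scatter, so no order among the three can be read.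

Compound 4, `N#Cc1c(Nc2ccccc2)nc(SCC(=O)Nn2c(COc3ccc(Cl)cc3Cl)nc3ccccc3c2=O)nc1-c1ccc(Cl)cc1`, has not been measured. It differs from compound 3 by chloro in place of hydrogen on an aromatic carbon, the same change as that from compound 1 to compound 2, at the same kind of place. Among the measured compounds shown here, the only guide is the single measured case, which gave a number 1.8 percentage points lower from compound 1 to compound 2 (within the scatter); on that basis the step in this assay is expected to be a number 1.6 percentage points lower from compound 3 to compound 4 (within the scatter), within the scatter. For compound 4 the expected value in this assay is 76.5%, estimated to lie between 70% and 83%.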

Compound 4, a percentage reported as inhibition, in the whole organism at one dose (the size of the read-out at that dose, not a potency): 56.1%
Compound 4: the middle estimate sits 20.4 percentage points above what was measured; the whole stated range lies above it.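

In this assay, phenyl to 4-chlorophenyl on the core of compound 3 gives a number 22 percentage points lower from compound 3 to compound 4 (beyond the scatter). The change therefore does not carry over at a constant size between these two cores: the same change on two cores in this assay, a number 1.8 percentage points lower (within the scatter) from compound 1 to compound 2 and a number 22 percentage points lower (beyond the scatter) from compound 3 to compound 4, 20.2 percentage points apart, beyond the scatter of two such steps This rests on one pair per core at one dose, so it shows that the size of the step differs between these two cores, but not which structural difference between the cores goes with the larger step, nor how the change would behave on any further core.

The compounds shown leave open whether the drop on the core of compound 3 is particular to chloro or would also appear with fluoro, methyl, methoxy or an amine in its place on the same ring. As far as these compounds go, it also remains open whether a group such as methoxy would give steps that differ between the two cores in the same way.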